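The compounds below may be only part of what the source reports. "The series", "measured", "known", "first", "only" and "open" are said of these compounds alone.

Compound 2 `COc1cc(Cc2cnc(/N=C3\C(=O)N(CN4CCN(c5ccc(F)cc5)CC4)c4ccc(Cl)cc43)nc2N)cc(OC)c1OC` is the compound to start from. Within the data shown here, in an ADME assay on CCRF-CEM cells (Homo sapiens) for cytotoxicity, read by MTT assay, with a stated time of 5 days (a lower number here means that less compound is tolerated, a higher number that more compound is tolerated), compound 2 gives 71 ug/mL, the highest of the three numbers measured so far. Compound 1 `COc1cc(Cc2cnc(/N=C3\C(=O)N(CN4CCN(c5c(F)cc6c(=O)c(C(=O)O)cn(C7CC7)c6c5F)CC4C)c4ccc(Cl)cc43)nc2N)cc(OC)c1OC` gives 67 ug/mL in this assay, a number within the scatter of compound 2, so the two cannot be told apart. Compound 3 `CCn1cc(C(=O)O)c(=O)c2cc(F)c(N3CCN(CN4C(=O)/C(=N\c5ncc(Cc6cc(OC)c(OC)c(OC)c6)c(N)n5)c5cc(Cl)ccc54)C(C)C3)c(F)c21` gives 18.7 ug/mL in this assay, the lowest of the three, with both other compounds beyond the scatter from it. Among the measured compounds shown here, the only pair of measured compounds that differ in one place is compound 1 and compound 3: a 3.6-fold lower number from compound 1 to compound 3 (0.55 log units; beyond the scatter). That change sits on an aromatic nitrogen in a large group that compound 2 does not carry at all, so it says nothing direct about compound 4 `COc1cc(Cc2cnc(/N=C3\C(=O)N(CN4CCN(c5cccc(Cl)c5)CC4)c4ccc(Cl)cc43)nc2N)cc(OC)c1OC`. Compound 4 differs from compound 2 in one place: 3-chlorophenyl in place of 4-fluorophenyl on an amine nitrogen in a ring. For the measured compounds named here, no measured step in this assay touches a group on this amine nitrogen, so there is nothing here that points to a shift in either direction. The step of a 1.1-fold lower number from compound 2 to compound 4 (0.06 log units; within the scatter) that the estimate means is therefore expected to stay within the scatter. The estimate for compound 4 in this assay is 62 ug/mL, in a range from 30 ug/mL to 130 ug/mL.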

Compound 4, half-maximal cytotoxic concentration: 34.4 ug/mL
Compound 4: middle estimate off by 1.8-fold (0.26 log units), on the high side; low and high end bracket the measured number.
By their numbers in this assay, from the lowest: compounds 3, 4, 1 and 2 (each within the scatter of the next, the first and the last beyond it).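

The group on this amine nitrogen is not a silent position in this assay: the swap of 4-fluorophenyl for 3-chlorophenyl gives a 2.1-fold lower number from compound 2 to compound 4 (0.31 log units; beyond the scatter), a modest step but one that lies beyond the scatter, so less of compound 4 is tolerated by the cells. Among these compounds, this is the first measured change at this nitrogen, as the only earlier step lay on an aromatic nitrogen in a large group that compounds 2 and 4 do not carry, and it shows that the number can move even when the entering and leaving groups match in heavy-atom count, aromatic ring, hydrogen-bond donors and acceptors, and net charge. Nothing available explains why the number moves at this position.

This single step changes the halogen and its place on the ring together, so it cannot show which of the two matters. A plain phenyl group or a pyridyl group on this nitrogen would show whether any halogen is needed for the number to shift, and whether a carbon-only aromatic ring is needed at all.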